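The source may report more compounds than this note shows. Statements on the series, on what has been measured and on what is new or still open speak of the compounds shown alone.

In a functional assay on HEK293 cells for agonist activity at Bombesin receptor subtype-3 (Mus musculus), read by luminescence and calcium flux, with a stated time of 10 min (a lower number here means that less compound is needed, a higher number that more compound is needed for the effect), the measured members of the series stand as follows:
compound 1 `CCC(C)(C)Cc1c[nH]c(CCc2ccc(-c3cccc(C)n3)cc2)n1`: 106 nM
compound 2 `CCC(C)(C)Cc1c[nH]c(CCc2ccc(-c3cccc(N)n3)cc2)n1`: 119 nM
compound 3 `CCC(C)(C)Cc1c[nH]c(CCc2ccc(N3CCCCC3)cc2)n1`: 133 nM

Compound 3 gives the highest of the three numbers, but the steps of a 1.3-fold higher number from compound 1 to compound 3 (0.10 log units; within the scatter) and a 1.1-fold higher number from compound 2 to compound 3 (0.05 log units; within the scatter) both stay within the scatter, so no order among these three can be read.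

Compound 4 `CCC(C)(C)Cc1c[nH]c(CCc2ccc(-c3ccns3)cc2)n1` differs from compound 3 by 1,2-thiazol-5-yl in place of piperidin-1-yl on an aromatic carbon. Within the data shown here, the steps that bear on this exchange are a 1.3-fold higher number from compound 1 to compound 3 (0.10 log units; within the scatter) and a 1.1-fold higher number from compound 2 to compound 3 (0.05 log units; within the scatter), each swapping an aromatic ring at this place for piperidin-1-yl without a change beyond the scatter. Among the measured compounds shown here, no measured step covers a five-membered aromatic ring, so the expectation rests on those two only. In this assay compound 4 is therefore expected to show no step beyond the scatter, a 1.2-fold lower number from compound 3 to compound 4 (0.06 log units; within the scatter). The estimate for compound 4 is 115 nM, with a range of 50 nM to 260 nM.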

Compound 4, half-maximal effective concentration: 103 nM
Compound 4: middle estimate off by 1.1-fold (0.05 log units), on the high side; the measured number falls inside the stated range.
By their numbers in this assay, from the lowest: compounds 4, 1, 2 and 3 (each within the scatter of the next).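

In this assay, a five-membered aromatic ring on this aromatic carbon gives no change beyond the scatter against piperidin-1-yl (a 1.3-fold lower number from compound 3 to compound 4 (0.11 log units; within the scatter)), 6-aminopyridin-2-yl (a 1.2-fold lower number from compound 2 to compound 4 (0.06 log units; within the scatter)) or 6-methylpyridin-2-yl (a 1.0-fold lower number from compound 1 to compound 4 (0.01 log units; within the scatter)). The position therefore accepts 1,2-thiazol-5-yl, with its sulfur, as readily as the six-membered rings, and no order can be read among the four compounds. No measurement on hand accounts for this flat result.

Still open, on these data alone, is whether any group here moves the number beyond the scatter. A carboxylic acid, a longer amine chain or a bare hydrogen at this place would test that.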